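Replacing cyclohexyl by 2-phenylphenyl: an expected value

The source may report more compounds than this note shows. Statements on the series, on what has been measured and on what is new or still open speak of the compounds shown alone.

Measured compounds in a functional assay on cells for inhibition of growth hormone secretagogue receptor type 1 (Homo sapiens), read by FLIPR and calcium flux; on this read-out higher numbers stand for an effect only at larger amounts of compound and lower numbers for an effect already at smaller amounts:
compound 1 `CC(C)(N)C(=O)N[C@H](COCc1ccccc1C(F)(F)F)c1nnnn1CCOC(=O)NCCCCO` gives 0.72 nM
compound 2 `CC(C)(N)C(=O)N[C@H](COCc1cccc(OC(F)(F)F)c1)c1nnnn1CCOC(=O)NCCCCO` gives 3.1 nM
compound 3 `CC(C)(N)C(=O)N[C@H](COCC1CCCCC1)c1nnnn1CCOC(=O)NCCCCO` gives 1.66 nM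

Compound 3 stands at the second highest number of the three. Its nearest neighbour is compound 2, and the step of a 1.9-fold lower number from compound 2 to compound 3 (0.27 log units; within the scatter) lies within the scatter. For the measured compounds named here, the step of a 2.3-fold higher number from compound 1 to compound 3 (0.36 log units; beyond the scatter) is beyond the scatter and modest, so compound 1 is the only measured compound set apart from compound 3.

Compound 4 `CC(C)(N)C(=O)N[C@H](COCc1ccccc1-c1ccccc1)c1nnnn1CCOC(=O)NCCCCO` is not yet measured. It differs from compound 3 in one place: 2-phenylphenyl in place of cyclohexyl on a saturated chain carbon bound to an oxygen on a saturated carbon. Going by the values given here, two measured steps bear on this change, both at the same place. The step of a 2.3-fold higher number from compound 1 to compound 3 (0.36 log units; beyond the scatter) shows that a phenyl carrying a group at its 2-position gave a lower number than cyclohexyl, while a 1.9-fold lower number from compound 2 to compound 3 (0.27 log units; within the scatter) shows that a phenyl substituted elsewhere was within the scatter of cyclohexyl. Among the compounds with values here, compound 4 also carries a phenyl substituted at the 2-position, so a modestly lower number is expected, close to compound 1 but uncertain in size because a 2.3-fold higher number from compound 1 to compound 3 (0.36 log units; beyond the scatter) is only a single step.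

The estimate for compound 4 is therefore 1 nM, with a range from 0.3 nM to 4 nM, which is the expected step of a 1.7-fold lower number from compound 3 to compound 4 (0.22 log units; within the scatter).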

Compound 4, half-maximal effective concentration: 0.34 nM
Compound 4: the middle estimate sits 2.9-fold (0.47 log units) above what was measured, within the range that was stated.
By their numbers in this assay, from the lowest: compound 4; then compound 1; then compounds 3 and 2 (each within the scatter of the next).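

In this assay, 2-phenylphenyl, with 12 heavy atoms against the 6 of cyclohexyl, is not just tolerated at this place: a 4.9-fold lower number from compound 3 to compound 4 (0.69 log units; beyond the scatter), and a 9.1-fold lower number from compound 2 to compound 4 (0.96 log units; beyond the scatter). The comparison within the substituted phenyl groups also adds something new, since a 2.1-fold lower number from compound 1 to compound 4 (0.33 log units; beyond the scatter), a change on an aromatic carbon that lies beyond the scatter. Among the four compounds shown, compound 4 therefore has the lowest number, so a second aromatic ring on the phenyl is compatible with an effect at smaller amounts of compound.

No measurement shown explains why the number falls with this change. As far as these compounds go, it also remains open how 2-benzylphenyl, with a longer link to its second ring, or a 2-phenylphenyl carrying an amine or a carboxylic acid would read at this place.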